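Fluoro to chloro on the aromatic ring of compound 3

The compounds below may be only part of what the source reports. "The series", "measured", "known", "first", "only" and "open" are said of these compounds alone.

Of the compounds shown here, three have been measured in an assay on isolated protein with Bile acid receptor (Homo sapiens) as the target; on this read-out higher numbers stand for an effect only at larger amounts of compound and lower numbers for an effect already at smaller amounts. Compound 1 `COC(=O)/C=C/c1cccc(N(Cc2ccc(/C=C/c3c(C)cc(C)cc3C)cc2)C(=O)NC(C)C)c1` gives 431 nM. Compound 2 `COC(=O)/C=C/c1cccc(N(Cc2ccc(/C=C/c3cccc(F)c3)cc2)C(=O)C2CCCCC2)c1` gives 86 nM in this assay, and compound 3 `COC(=O)/C=C/c1cccc(N(Cc2ccc(/C=C/c3cccc(F)c3)cc2)C(=O)C(C)C)c1` gives 71 nM. Compound 3 thus holds the lowest of the three numbers, though a 1.2-fold lower number from compound 2 to compound 3 (0.08 log units; within the scatter) stays within the scatter, whereas compound 1 stands beyond it.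

Compound 4 `COC(=O)/C=C/c1cccc(N(Cc2ccc(/C=C/c3cccc(Cl)c3)cc2)C(=O)C(C)C)c1` has not yet been measured. It differs from compound 3 in one place: chloro in place of fluoro on an aromatic carbon. The change sits on an aromatic carbon of a six-membered aromatic ring of carbon only, meta to a large group. For the measured compounds named here, no measured step in this set touches that position: the single one-point step, from compound 2 to compound 3, alters the group on the carbonyl carbon, and compound 1 differs from compound 3 in several places at once. The shown numbers therefore give no ground for a step beyond the scatter in this assay in either direction.

For compound 4 the expected value is 65 nM, with a range from 25 nM to 160 nM. For compound 4 the expected step is a 1.1-fold lower number from compound 3 to compound 4 (0.04 log units; within the scatter).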

Compound 4, half-maximal effective concentration: 164 nM
Compound 4: middle estimate off by 2.5-fold (0.40 log units), on the low side; measured number above the stated range.
By their numbers in this assay, from the lowest: compounds 3, 2 and 4 (each within the scatter of the next, the first and the last beyond it); then compound 1.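

In this assay, for the compounds shown here, the change from 3-fluorophenyl to 3-chlorophenyl gives the first one-point reading at this position: a 2.3-fold higher number from compound 3 to compound 4 (0.36 log units; beyond the scatter) is modest, but it shows that exchanging one halogen for another on this aromatic carbon can move the number. The earlier one-point step, isopropyl in place of cyclohexyl on a carbonyl carbon, gave only a 1.2-fold lower number from compound 2 to compound 3 (0.08 log units; within the scatter) and so showed no change beyond the scatter. Nothing at hand accounts for the higher number with chloro.

From the compounds shown here alone, whether bromo, trifluoromethyl, methoxy or an amine on the same aromatic carbon would continue this step or reverse it remains open. Also open, going by these compounds, is whether chloro in place of fluoro gives a similar step when cyclohexyl replaces isopropyl on the carbonyl carbon.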